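This account rests on a few compounds, and the source may have more. Where it says the series, first, only, none or still open, it means among the compounds named here.

Working notes on a small series tested in an assay on membranes from CHO cells for displacement of a labelled ligand from adenosine receptor A1 (Homo sapiens), read by scintillation counting, with a stated time of 60 min, tested at 1 uM; a higher number here means more inhibition at the concentration tested (going by the name of the read-out), a lower number less inhibition.

Compound 1 `CCC(C)OC(=O)C1=C(C)NC(=O)NC1c1ccco1` gives 6% in this assay. Compound 2 `CC1=C(C(=O)OC2CCC2)C(c2ccco2)NC(=O)N1` gives 19%. Compound 3 `CCC(C)OC(=O)C1=C(C)NC(=O)NC1c1ccoc1` gives 13%. Compound 4 `CC1=C(C(=O)OC2CCC2)C(c2ccoc2)NC(=O)N1` has not yet been measured in this assay.

The change from compound 1 to compound 2 is cyclobutyl in place of sec-butyl on an oxygen next to a carbonyl group; the step it made was a number 13 percentage points higher from compound 1 to compound 2 (beyond the scatter). The change from compound 1 to compound 3 is furan-3-yl in place of furan-2-yl on a saturated ring carbon, and the step was a number 7 percentage points higher from compound 1 to compound 3 (within the scatter).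

Compound 4 differs from compound 3 by cyclobutyl in place of sec-butyl on an oxygen next to a carbonyl group. This is the same change as that from compound 1 to compound 2, made on a core that differs as described for compound 3 against compound 1. Within the data shown here, with only one earlier occurrence to go on, a step of similar size is expected from compound 3 to compound 4, because the step of a number 13 percentage points higher from compound 1 to compound 2 (beyond the scatter) is the only guide.

The expected step is a number 11 percentage points higher from compound 3 to compound 4 (beyond the scatter). Compound 4 is estimated at 24%, with a likely range from 10% to 38%.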

Compound 4, a percentage reported as inhibition, at one concentration (the size of the read-out at that concentration, not a potency): 20%
For compound 4 the middle estimate is 4 percentage points above the measured one, and the stated range covers the measured number.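

In this assay the cyclobutyl for sec-butyl change gives a number 7 percentage points higher from compound 3 to compound 4 (within the scatter), and the two occurrences of this change do not differ beyond the scatter: the same change on two cores in this assay, a number 13 percentage points higher (beyond the scatter) from compound 1 to compound 2 and a number 7 percentage points higher (within the scatter) from compound 3 to compound 4, 6 percentage points apart, within the scatter of two such steps. The furan-3-yl for furan-2-yl change gives a number 1 percentage points higher from compound 2 to compound 4 (within the scatter), and its two occurrences likewise do not differ beyond the scatter: the same change on two cores in this assay, a number 7 percentage points higher (within the scatter) from compound 1 to compound 3 and a number 1 percentage points higher (within the scatter) from compound 2 to compound 4, 6 percentage points apart, within the scatter of two such steps. Within these four compounds, neither change reads differently on the second core, but this does not establish a gain from cyclobutyl on the core of compound 3, where the step on its own lies within the scatter, and two occurrences of each change say nothing about other cores.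

All four compounds carry a furan ring and a four-carbon group on the ester oxygen, and a single-concentration read-out gives no potency for any of them. Going by these compounds, what a phenyl ring in place of the furan, or a longer chain or an amide in place of the ester, would do remains open.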